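Diarylalkylamine series: removing the tertiary hydroxy

The source may report more compounds than this note shows. Statements on the series, on what has been measured and on what is new or still open speak of the compounds shown alone.

Measured so far:
compound 1, `CC1CCN(CCC=C(c2ccccc2)c2ccccc2)CC1`, 1.9 nM
compound 2, `CC1CCN(CCCCC(c2ccccc2)c2ccccc2)CC1`, 0.09 nM
compound 3, `CCN(CC)CCCCC(O)(c1ccccc1)c1ccccc1`, 12 nM

In an assay on isolated protein for binding affinity to Sigma non-opioid intracellular receptor 1 (Homo sapiens), read by radioligand binding (a lower number here means a stronger inhibitor, a higher number a weaker inhibitor), the three measured compounds are spread widely. Compound 3 gives the highest number of the three in this assay. Its nearest neighbour is compound 1, which sits lower by a margin beyond the scatter; the furthest is compound 2, which gives the lowest number of the set, again well beyond the scatter.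

The next compound to be tested, compound 4 `CCN(CC)CCCCC(c1ccccc1)c1ccccc1`, keeps the diethylamino chain of compound 3 and differs only at the carbon carrying the two phenyl rings: hydrogen in place of hydroxy on a saturated chain carbon bound to two aromatic carbons and a saturated chain carbon.

Within the data shown here, no measured pair isolates this change, so its size in this assay cannot be read off directly. Both measured compounds that carry hydrogen at that position, compound 1 and compound 2, give lower numbers than compound 3, but each also differs in the amine and in the chain, so this is only a pointer. A step downward beyond the scatter is expected, a 6.0-fold lower number from compound 3 to compound 4 (0.78 log units; beyond the scatter), though smaller than the gap to compound 2. Compound 4 is therefore estimated at 2 nM, within 0.4 nM to 10 nM.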

Compound 4, inhibition constant: 1.4 nM
Beside the measured number, compound 4's estimate is 1.4-fold (0.15 log units) above it; the measured number falls inside the stated range.
By their numbers in this assay, from the lowest: compound 2; then compounds 4 and 1 (each within the scatter of the next); then compound 3.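

In this assay, hydrogen in place of hydroxy on a saturated chain carbon bound to two aromatic carbons and a saturated chain carbon gives an 8.6-fold lower number from compound 3 to compound 4 (0.93 log units; beyond the scatter), so the change can now be read with the diethylamino chain held constant rather than inferred from compounds that also differ in the amine and chain. The amine end now has a reading of its own, with the hydrogen-bearing chain held constant: diethylamino in place of 4-methylpiperidin-1-yl on a saturated chain carbon, five bonds along the chain from two aromatic carbons, gives a 16-fold higher number from compound 2 to compound 4 (1.19 log units; beyond the scatter). No supporting data explain either step.

Still open, as far as these compounds go, is whether the hydroxy-to-hydrogen step keeps its size with 4-methylpiperidin-1-yl at the chain end, and how fluorine or methoxy at the same carbon would compare with hydrogen and hydroxy. Also open, from the compounds shown here alone, is how far the reading at the amine end extends to other amines, such as dimethylamino or unsubstituted piperidin-1-yl, or to a shorter or longer chain.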